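No Measured Number Yet: From Urea to Ethoxy Carbonyl

A few compounds are considered here, and "the series" means these few. Any claim that something is new, unique, unknown or untested is made for them only; others in the source may bear on it.

Compound 1 `CC(C)c1ccc(C2CN(C)Cc3c(N)cccc32)cc1`: > 80 mg/kg
Compound 2 `CCCNC(=O)Nc1cccc2c1CN(C)CC2c1ccccc1`: > 80 mg/kg

In a functional assay on the whole organism for inhibition, with Mus musculus as the target (on this read-out lower numbers stand for an effect already at smaller amounts and higher numbers for an effect only at larger amounts of compound), compound 2 gives > 80 mg/kg, which is a limit of the assay and not a number. Compound 1 gives > 80 mg/kg, which is also a limit. Both compounds therefore stand at the same mark: the limit of > 80 mg/kg in this assay, at which 2 of the 2 values shown sit.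

Compound 3 `CCOC(=O)Nc1cccc2c1CN(C)CC2c1ccccc1` keeps the rest of compound 2 but carries ethoxy in place of propylamino on a carbonyl carbon. For the measured compounds named here, no measured pair shows what this exchange does. Compound 2 offers only > 80 mg/kg as a starting point, so the expectation stays close to that limit. The expected change is a number no higher from compound 2 to compound 3 (the limit leaves the size open), which means no move beyond the scatter in either direction, and the assay may again report only a limit. For compound 3 the estimated value is 80 mg/kg, with an expected range from 35 mg/kg to 160 mg/kg.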

Compound 3, dose for half-maximal effect: 3.2 mg/kg
For compound 3 the middle estimate is 25-fold (1.40 log units) above the measured one; the measured number lies below the stated range.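

In this assay, the carbonyl carbon on the amide-type nitrogen proves to be a place where a single exchange counts: ethoxy in place of propylamino gives an at least 25-fold lower number from compound 2 to compound 3 (1.39 log units; beyond the scatter), and compound 3 carries the only real number among the compounds shown. Compound 2 gives > 80 mg/kg, which is a limit of the assay and not a number, so this step has a known minimum but no known full size. The other values shown stay at that mark: the limit of > 80 mg/kg in this assay, at which 2 of the 3 values shown sit.

This one exchange swaps a nitrogen for an oxygen, removes the hydrogen-bond donor and shortens the chain together, so the compounds shown cannot say which of these matters. As far as these compounds go, it also remains open whether a methoxy group, a longer butoxy chain or a simple methyl on the same carbonyl would keep the effect.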